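Bromine on the phenyl ring of a triazolethione series

A few compounds are considered here, and "the series" means these few. Any claim that something is new, unique, unknown or untested is made for them only; others in the source may bear on it.

Two members of a shared core have been measured. Compound 1 `COc1ccccc1-n1c(Nc2nc(-c3ccc(Br)cc3)cs2)n[nH]c1=S` carries a bromophenyl group on its thiazole part and a methoxyphenyl group on its triazole part; in a functional assay on the whole organism (strain Swiss albino) for inhibition, with Mus musculus as the target, with a stated time of 4 h (on this read-out higher numbers stand for an effect only at larger amounts of compound and lower numbers for an effect already at smaller amounts), compound 1 gives 300 mg/kg. Compound 2 `Cc1ccc(-n2c(Nc3nc(-c4ccccc4)cs3)n[nH]c2=S)cc1` instead bears a plain phenyl group on the thiazole and a methylphenyl group on the triazole; in this assay compound 2 gives 300 mg/kg, level with compound 1 at the digits recorded and within the scatter of it. On the numbers shown, compound 2 therefore stands at the same dose as its only comparator.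

Compound 3 `Cc1ccc(-n2c(Nc3nc(-c4ccc(Br)cc4)cs3)n[nH]c2=S)cc1` is yet to be measured. It differs from compound 2 by a single change: bromo in place of hydrogen on an aromatic carbon. Read one bond further out, phenyl becomes 4-bromophenyl, the same group that compound 1 already carries, and compound 1 gives 300 mg/kg. Since both measured compounds sit at one dose, the expected step of no change at the digits printed from compound 2 to compound 3 (within the scatter) is none beyond the scatter. Compound 3 is estimated at 300 mg/kg, with a range from 150 mg/kg to 600 mg/kg.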

Compound 3, minimum effective dose: 300 mg/kg
Compound 3: the middle estimate sits on the measured number at the digits printed; the measured number falls inside the stated range.
By their numbers in this assay, from the lowest: compounds 1, 2 and 3 (each within the scatter of the next).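

In this assay, bromo in place of hydrogen on an aromatic carbon, para to a large group, gives no change at the digits printed from compound 2 to compound 3 (within the scatter), so with the 4-methylphenyl group held fixed, phenyl and 4-bromophenyl cannot be told apart on this read-out. Compound 3 also shares the 4-bromophenyl group of compound 1, and 4-methylphenyl in place of 2-methoxyphenyl on an aromatic nitrogen gives no change at the digits printed from compound 1 to compound 3 (within the scatter); compounds 1 and 2 differed in both places at once, whereas these two steps read each place alone and neither goes beyond the scatter. Nothing at hand bears on why the doses coincide.

All three compounds stand at one printed dose, so the compounds shown do not reveal whether either place can move the minimum effective dose at all. From the compounds shown here alone, it remains open whether an amine or a carboxylic acid in place of the bromo, or a longer chain in place of the 4-methylphenyl group on the aromatic nitrogen, would separate from these compounds in this assay and beyond the scatter.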